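The compounds below may be only part of what the source reports. "The series", "measured", "known", "first", "only" and "open" are said of these compounds alone.

Compound 1 `Cc1c(C)c2c(c(C)c1NC=O)CC(C)(C)O2`: > 100 mg/kg
Compound 2 `Cc1ccc(S(=O)(=O)Nc2c(C)c(C)c3c(c2C)CC(C)(C)O3)cc1`: > 100 mg/kg

In a functional assay on the whole organism with Mus musculus as the target (on this read-out higher numbers stand for an effect only at larger amounts of compound and lower numbers for an effect already at smaller amounts), compound 1 gives > 100 mg/kg, which is a limit and not a number. Compound 2 gives > 100 mg/kg, also a limit. Within the data shown here, the record therefore shows only (the limit of > 100 mg/kg in this assay, at which 2 of the 2 values shown sit), and compound 1 stands there with no measured step to size a change. Compound 3 `Cc1c(C)c2c(c(C)c1Nc1ccccc1)CC(C)(C)O2` carries phenyl in place of formyl on a nitrogen on an aromatic ring. A clear move towards smaller doses is expected, though this is a tentative judgement, and the estimated change is an at least 3.3-fold lower number from compound 1 to compound 3 (0.52 log units; beyond the scatter). Compound 3 is expected at 30 mg/kg, with an estimated range of 8 mg/kg to 100 mg/kg.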

Compound 3, dose for 50% inhibition: > 50 mg/kg
Compound 3 gave a limit, no number; the forecaster's own chance of this, stated with the estimate: 35%; middle value at least 1.6-fold (0.22 log units) from the limit.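

Among these compounds, compound 3 gives > 50 mg/kg as a limit and compound 1 also stands at a limit, so no step between compound 1 and compound 3 can be read. In this assay the compounds shown leave open what dose any of them needs.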